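This account rests on a few compounds, and the source may have more. Where it says the series, first, only, none or still open, it means among the compounds named here.

In a functional assay on MIA PaCa-2 cells (Homo sapiens) for inhibition, read by MTT assay, with a stated time of 3 days (on this read-out higher numbers stand for weaker inhibition and lower numbers for stronger inhibition), compound 1, whose structure is `CCN(CC)S(=O)(=O)c1ccc(S(=O)(=O)N2CCC[C@@H](C(=O)N[C@@H]3CCN(C(=O)OC(C)(C)C)C3)C2)cc1`, gives > 10000 nM, which is a limit of the assay and not a number. The two other measured compounds tell the same story. Compound 2, built as `CCCN(CCC)S(=O)(=O)c1ccc(S(=O)(=O)N2CCC[C@@H](C(=O)OCC)C2)cc1`, gives > 10000 nM in this assay, again a limit rather than a number. Compound 3, with the structure `CCN(CC)S(=O)(=O)c1ccc(S(=O)(=O)N2CCC[C@@H](C(=O)N3CCC(c4nc(C(C)C)no4)CC3)C2)cc1`, likewise gives > 10000 nM in this assay, a limit only. Where compound 1 stands is therefore fixed only by the limit of > 10000 nM in this assay, at which 3 of the 3 values shown sit, and no measured step between any two of these compounds exists.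

Compound 4 is `CCN(CC)S(=O)(=O)c1ccc(S(=O)(=O)N2CCC[C@@H](C(=O)NC3CN(C(=O)OC(C)(C)C)C3)C2)cc1`. It differs from compound 1 by 1-(tert-butoxycarbonyl)azetidin-3-yl in place of 1-(tert-butoxycarbonyl)pyrrolidin-3-yl on an amide-type nitrogen. With three compounds that share the core of compound 1 all sitting at the limit, no direction for such a change can be read from the data. The step from compound 1 to compound 4 is expected to be a step that the limit leaves unreadable from compound 1 to compound 4, that is, none beyond the scatter. For compound 4 in this assay the estimate is 15000 nM, with a range from 5000 nM to 50000 nM, and a reading that is again only a limit is expected to be the most likely outcome.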

Compound 4, half-maximal inhibitory concentration: > 10000 nM
Compound 4: a limit, no number; the forecaster's own chance of this, stated with the estimate: 85%; the middle value is on the limit's open side.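

Compound 1 and compound 4 each give only a limit in this assay, not a number, so no step between them can be read: the limit of > 10000 nM in this assay, at which 4 of the 4 values shown sit.

The compounds shown leave open whether any change on the shared core would give a number in this assay.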